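A few compounds are considered here, and "the series" means these few. Any claim that something is new, unique, unknown or untested is made for them only; others in the source may bear on it.

Working notes on the series. Three compounds share the fused core and are characterised in an assay on HEK293 cells for binding affinity to Neuronal acetylcholine receptor; alpha4/beta2 (Homo sapiens); on this read-out lower numbers stand for stronger inhibition and higher numbers for weaker inhibition. Compound 1 `CC(=O)c1ccc2c(c1)C1CNCC2C1` gives 0.17 nM in this assay. Compound 2 `Cc1nc2cc3c(cc2[nH]1)C1CNCC3C1` gives 0.1 nM, and compound 3 `c1nc2cc3c(cc2[nH]1)C1CNCC3C1` gives 0.15 nM. Among the measured compounds shown here, compound 2 sits at the low end of the three numbers, though neither gap separates it from the others: the only single-point step recorded, a 1.5-fold higher number from compound 2 to compound 3 (0.18 log units; within the scatter), is within the scatter, and the number for compound 1 is likewise within the scatter of compound 2.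

The next compound, compound 4 `CCCn1c(C)nc2cc3c(cc21)C1CNCC3C1`, is not yet measured in this assay. It differs from compound 2 by propyl in place of hydrogen on an aromatic nitrogen. For the measured compounds named here, no measured step touches this nitrogen; the one step in hand, a 1.5-fold higher number from compound 2 to compound 3 (0.18 log units; within the scatter), concerns the methyl on an aromatic carbon and was flat. There is therefore no basis in the data for predicting a step of any particular size or direction, and the estimate carries a wide range. Compound 4 is expected to give 0.5 nM in this assay, between 0.1 nM and 3 nM, which corresponds to an expected 5.0-fold higher number from compound 2 to compound 4 (0.70 log units; beyond the scatter).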

Compound 4, inhibition constant: 0.19 nM
For compound 4 the middle estimate is 2.6-fold (0.42 log units) above the measured one; measured number inside the range.
By their numbers in this assay, from the lowest: compounds 2, 3, 1 and 4 (each within the scatter of the next).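

Substitution on the aromatic nitrogen, a position no earlier step touched, can now be read: in this assay, propyl in place of hydrogen gives a 1.9-fold higher number from compound 2 to compound 4 (0.28 log units; within the scatter). Compound 4, which has no hydrogen on this nitrogen and carries propyl on the atom next to the ring atom that bears a methyl group, thus stands within the scatter of compound 2. No measurement shown accounts for this result.

Going by these compounds, whether a longer chain, a benzyl group or a chain ending in a carboxylic acid on this nitrogen would also stay within the scatter of compound 2 remains open. Also open, on these data alone, is how propyl on this nitrogen reads when the neighbouring methyl group is replaced by hydrogen.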